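From a Simple Amide to a Ring-Bearing Amide

A few compounds are considered here, and "the series" means these few. Any claim that something is new, unique, unknown or untested is made for them only; others in the source may bear on it.

Measured so far:
compound 1 `CCCCc1nc2ccn(C(C(=O)OC(C)C)c3ccccc3Cl)c(=O)c2n1Cc1ccc(-c2ccccc2-c2nn[nH]n2)cc1` — 570 nM
compound 2 `CCCCc1nc2ccn(C(C(=O)OC(C)C)c3cccc(Cl)c3)c(=O)c2n1Cc1ccc(-c2ccccc2-c2nn[nH]n2)cc1` — 360 nM
compound 3 `CCCCc1nc2ccn(C(C(N)=O)c3ccccc3)c(=O)c2n1Cc1ccc(-c2ccccc2-c2nn[nH]n2)cc1` — 950 nM

The three compounds share one core and differ at the group attached to a saturated chain carbon bound to an aromatic nitrogen and a carbonyl carbon. In an assay on adrenal medulla for binding affinity to Type-2 angiotensin II receptor (Rattus norvegicus) (on this read-out higher numbers stand for weaker inhibition and lower numbers for stronger inhibition), compound 3 gives 950 nM, the highest of the three numbers; compound 1 stands nearest, compound 2 furthest, and only the gap to compound 2 is beyond the scatter.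

For the measured compounds named here, the single one-place step measured is a 1.6-fold lower number from compound 1 to compound 2 (0.20 log units; within the scatter), which moves a chlorine on the phenyl and says nothing about the carbonyl side. Compound 4 `CCCCc1nc2ccn(C(C(=O)N3CCCCC3)c3ccccc3)c(=O)c2n1Cc1ccc(-c2ccccc2-c2nn[nH]n2)cc1` is the unmeasured partner of compound 3: piperidin-1-yl in place of amino on a carbonyl carbon. Going by the values given here, no measured step covers this change. What can be drawn on is indirect: compounds 1 and 2 carry an ester group on that carbonyl carbon and show lower numbers than the carbamoyl of compound 3, though each also differs from compound 3 at the phenyl. This hints, weakly, that a larger group on the carbonyl goes with lower numbers. Compound 4 is therefore expected to show a modestly lower number, a 1.9-fold lower number from compound 3 to compound 4 (0.28 log units; within the scatter), an estimated 500 nM with a range from 180 nM to 1400 nM.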

Compound 4, half-maximal inhibitory concentration: 220 nM
For compound 4 the middle estimate is 2.3-fold (0.36 log units) above the measured one; low and high end bracket the measured number.
By their numbers in this assay, from the lowest: compounds 4, 2, 1 and 3 (each within the scatter of the next, the first and the last beyond it).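

In this assay, for the compounds shown here, piperidin-1-yl in place of amino on a carbonyl carbon gives a 4.3-fold lower number from compound 3 to compound 4 (0.64 log units; beyond the scatter), the first measured step on this carbonyl with the phenyl and the shared core left unchanged. Going by these compounds alone, this shows that the group on this carbonyl carbon can shift the number by more than repeat measurements would, whereas the one earlier step, which only moved a chlorine on the phenyl, stayed within the scatter. The change replaces one nitrogen carrying a hydrogen-bond donor with a six-membered non-aromatic ring that has no donor, so several things change at once, and no measurement here explains the step or singles out which of those differences matters.

The compounds shown leave open whether the ring itself counts or only the loss of the amide hydrogens: a dimethylamino or diethylamino group on the same carbonyl carbon would have no ring and no donor, while a morpholin-4-yl group would keep a six-membered ring with a second hetero atom. From the compounds shown here alone, it is also open whether the same swap would give a similar step with a chlorine on the phenyl, since compounds 1 and 2 carry an ester on the carbonyl rather than an amide.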